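The source may hold more compounds than are shown below. What is called first, only, known or untested is meant among the compounds shown, and "the series" means these compounds.

Of the compounds shown here, three have been measured so far in a functional assay (aorta) with Oryctolagus cuniculus as the target; a lower number here means a stronger inhibitor, a higher number a weaker inhibitor. Among the measured compounds shown here, compound 1 `OCc1ccc(-c2nn(Cc3cccnc3)c3ccccc23)o1` gives 9600 nM, and compound 2 `OCc1ccc(-c2nn(Cc3cncnc3)c3ccccc23)o1` gives 3200 nM; the one change between them produced a 3.0-fold lower number from compound 1 to compound 2 (0.48 log units; beyond the scatter). Compound 3 `Nc1nc(-c2nn(Cc3ccccc3F)c3ncccc23)ncc1C1CCC1`, built on a different core, gives 633000 nM, the highest number of the three. Compound 4 `CC(C)S(=O)(=O)c1cnc(-c2nn(Cc3ccccc3F)c3ncccc23)nc1N` differs from compound 3 by one change: isopropylsulfonyl in place of cyclobutyl on an aromatic carbon. For the measured compounds named here, no measured step involves this kind of swap, and the only step recorded, from compound 1 to compound 2, concerns another group on another core, so it gives no direct guide. Compound 4 is therefore expected to land near compound 3, with a step of about a 2.5-fold lower number from compound 3 to compound 4 (0.40 log units; beyond the scatter), and its estimated value is 250000 nM, between 40000 nM and 1500000 nM.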

Compound 4, half-maximal inhibitory concentration: 517000 nM
Compound 4: the middle estimate sits 2.1-fold (0.32 log units) below what was measured; the measured number falls inside the stated range.
By their numbers in this assay, from the lowest: compound 2; then compound 1; then compounds 4 and 3 (each within the scatter of the next).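

In this assay, isopropylsulfonyl in place of cyclobutyl on this aromatic carbon gives a 1.2-fold lower number from compound 3 to compound 4 (0.09 log units; within the scatter), so the two compounds cannot be told apart here. At this position, a four-membered carbon ring and an open group with two hydrogen-bond acceptors read alike, something the earlier step on another core could not show. On these data alone, whether an amine or a carboxylic acid on this carbon would give a clearly different number stays open. Nothing measured on hand offers an explanation for this result.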